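Isopropyl for Methyl: Expected Plasma Free Fraction

This account rests on a few compounds, and the source may have more. Where it says the series, first, only, none or still open, it means among the compounds named here.

Compound 1 `CS(=O)(=O)c1ccc(F)c(C#Cc2cc(Cl)ccc2OCC(=O)O)c1`: 0.011
Compound 2 `COCCNS(=O)(=O)c1ccc(C)c(C#Cc2cc(Cl)ccc2OCC(=O)O)c1`: "not determined" (no result reported)
Compound 3 `Cc1ccc(S(C)(=O)=O)cc1C#Cc1cc(Cl)ccc1OCC(=O)O`: 0.014

Three compounds sharing one core were studied in an ADME assay on a cell-free system (plasma, Rattus norvegicus); on this read-out lower numbers stand for a smaller free fraction and higher numbers for a larger free fraction. In this assay compound 1 gives 0.011, and compound 3 gives 0.014. Within the data shown here, for compound 2 the entry reads "not determined" (no result reported), so only two numbers exist. Among the measured compounds shown here, compound 3 has the higher of the two, but the single step of a 1.3-fold higher number from compound 1 to compound 3 (0.10 log units; within the scatter) is within the scatter, so the two compounds cannot be told apart on this read-out.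

Compound 4 `CC(C)c1ccc(S(C)(=O)=O)cc1C#Cc1cc(Cl)ccc1OCC(=O)O` is not yet measured. It differs from compound 3 in one place: isopropyl in place of methyl on an aromatic carbon. For the measured compounds named here, only the step from compound 1 to compound 3 bears on this change, and it was small; it also swapped a different pair of groups, so it gives little direct guidance. Exchanging one carbon for three at the same position is expected to lower the free fraction, most likely by a modest amount, and the step of a 1.8-fold lower number from compound 3 to compound 4 (0.24 log units; within the scatter) is estimated as a decrease. Compound 4 is therefore expected to give about 0.008, within a range from 0.004 to 0.016.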

Compound 4, unbound fraction: 0.004
The estimate for compound 4 lay 2.0-fold (0.30 log units) above the measured number, within the range that was stated.
By their numbers in this assay, from the lowest: compound 4; then compounds 1 and 3 (each within the scatter of the next).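

In this assay, the aromatic carbon para to a methylsulfonyl group now shows a change that can be read: isopropyl in place of methyl gives a clear drop (a 3.5-fold lower number from compound 3 to compound 4 (0.54 log units; beyond the scatter)), while the earlier swap of fluoro for methyl at this carbon could not be told from repeat-measurement noise (a 1.3-fold higher number from compound 1 to compound 3 (0.10 log units; within the scatter)). Isopropyl also stands apart from fluoro (a 2.8-fold lower number from compound 1 to compound 4 (0.44 log units; beyond the scatter)), so among these three compounds the group at this carbon can shift the free fraction, and the isopropyl compound has the smallest free fraction of the three. Nothing measured here explains why this exchange lowers the number.

From the compounds shown here alone, with only fluoro, methyl and isopropyl at this carbon, it remains unknown whether the free fraction would keep falling with a tert-butyl group or a longer chain such as n-butyl, or whether a ring such as cyclopropyl would behave like isopropyl. Going by these compounds, it also remains open how a group of a different kind at this carbon, such as an amine or a hydroxyl, would compare with these three.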